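The compounds below may be only part of what the source reports. "The series", "measured", "known", "first", "only" and "open" are said of these compounds alone.

Three compounds have been measured in a functional assay on HepG2 cells (Homo sapiens) for antiproliferative activity, read by MTT assay, with a stated time of 48 h; on this read-out higher numbers stand for weaker inhibition and lower numbers for stronger inhibition:

Compound 1 `Cc1ccc(NC(=O)Nc2cccc(CNc3nccnc3Cl)c2)cc1C`: 10700 nM
Compound 2 `Cc1ccccc1NC(=O)Nc1cccc(CNc2nccnc2Cl)c1`: 15300 nM
Compound 3 `O=C(Nc1cccc(CNc2nccnc2Cl)c1)Nc1ccc(Cl)cc1Cl`: 7230 nM

Compound 1 has the second highest number of the three. Its nearest neighbour is compound 2, reached by a 1.4-fold higher number from compound 1 to compound 2 (0.16 log units; within the scatter), and its furthest is compound 3, reached by a 1.5-fold lower number from compound 1 to compound 3 (0.17 log units; within the scatter); both steps are within the scatter, so the three values cannot be told apart with confidence. Compound 4 `CCc1ccccc1NC(=O)Nc1cccc(CNc2nccnc2Cl)c1` differs from compound 1 by 2-ethylphenyl in place of 3,4-dimethylphenyl on an amide-type nitrogen. The step from compound 1 to compound 2 changed the same group in the same place and stayed within the scatter, and the step from compound 1 to compound 3 did likewise. On that basis no step beyond the scatter is expected, a 1.2-fold higher number from compound 1 to compound 4 (0.07 log units; within the scatter). Compound 4 is therefore estimated at 12500 nM, with a range from 6000 nM to 26000 nM.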

Compound 4, half-maximal inhibitory concentration: 7860 nM
Estimate against measurement, compound 4: 1.6-fold (0.20 log units) above; low and high end bracket the measured number.
By their numbers in this assay, from the lowest: compounds 3, 4, 1 and 2 (each within the scatter of the next, the first and the last beyond it).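

In this assay, moving from 3,4-dimethylphenyl to 2-ethylphenyl on the amide-type nitrogen, with the same count of carbons, gives a 1.4-fold lower number from compound 1 to compound 4 (0.13 log units; within the scatter) and so no change that can be read. Compound 4 also lies within the scatter of both other compounds, with a 1.1-fold higher number from compound 3 to compound 4 (0.04 log units; within the scatter) and, for extending 2-methylphenyl to 2-ethylphenyl, a 1.9-fold lower number from compound 2 to compound 4 (0.29 log units; within the scatter) as the step. No measurement is available that could explain these results.

As far as these compounds go, it remains open whether an amine or a carboxylic acid on this phenyl ring, or a longer chain in place of the ethyl, would give a step beyond the scatter.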